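Trifluoromethyl in place of methoxy: notes on the series

This account rests on a few compounds, and the source may have more. Where it says the series, first, only, none or still open, it means among the compounds named here.

Measured in a functional assay on the whole organism with Mus musculus as the target; on this read-out higher numbers stand for an effect only at larger amounts of compound and lower numbers for an effect already at smaller amounts:
- compound 1 `NC(=O)CNCc1ccccc1`: 490 mg/kg
- compound 2 `CN(CC(N)=O)Cc1ccc(OCc2cccc(Cl)c2)cc1`: 114 mg/kg
- compound 3 `CNC(=O)[C@@H](CO)NCc1ccc(OCc2cccc(OC)c2)cc1`: 109 mg/kg

Compound 3 stands beyond the scatter from compound 1, on the side of smaller doses, and within the scatter of compound 2 at 114 mg/kg. The next structure, compound 4 `CNC(=O)[C@@H](CO)NCc1ccc(OCc2cccc(C(F)(F)F)c2)cc1`, carries trifluoromethyl in place of methoxy on an aromatic carbon.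

Among the compounds with values here, no measured pair differs in only one place, so this assay offers no direct precedent for this exchange. Compound 2 and compound 3 differ in several places, yet their values lie within the scatter of each other, which gives a weak reason to expect little movement here. No step beyond the scatter is expected: the estimated change is a 1.1-fold lower number from compound 3 to compound 4 (0.04 log units; within the scatter). The estimate for compound 4 is 100 mg/kg, with an expected range from 45 mg/kg to 220 mg/kg.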

Compound 4, dose for half-maximal effect: 19.5 mg/kg
Compound 4: middle estimate off by 5.1-fold (0.71 log units), on the high side, outside the stated range (below it).
By their numbers in this assay, from the lowest: compound 4; then compounds 3 and 2 (each within the scatter of the next); then compound 1.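

Within the data shown here, this is the only single-place exchange, and it shows that in this assay the group on this aromatic carbon, meta to a large group, matters: trifluoromethyl in place of methoxy gives a 5.6-fold lower number from compound 3 to compound 4 (0.75 log units; beyond the scatter) on an otherwise unchanged structure. The earlier compounds shown here could not show this, as compound 2 and compound 3 differ in several places and their closeness says nothing about any single position. No measurement in hand accounts for the step.

On these data alone, whether this step is particular to trifluoromethyl remains open, since a nitrile, an ethoxy group or a longer chain on the same carbon would test how far it extends. The compounds shown also leave open whether the same exchange carries over to the core of compound 2.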